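Methoxy in Place of Methyl on a Second Aryl Core

The source may hold more compounds than are shown below. What is called first, only, known or untested is meant among the compounds shown, and "the series" means these compounds.

Compound 1, `Cc1ccccc1-c1nnc(SCCn2c([N+](=O)[O-])cnc2C)o1`, was tested in a functional assay on SGC-7901 cells (Homo sapiens) for cytotoxicity, read by MTT assay, with a stated time of 48 h (a higher number here means a weaker inhibitor, a lower number a stronger inhibitor), and gives 32300 nM. Compound 2, `COc1ccccc1-c1nnc(SCCn2c([N+](=O)[O-])cnc2C)o1`, differs from it by methoxy in place of methyl on an aromatic carbon, and in this assay compound 2 gives 30500 nM; the step is a 1.1-fold lower number from compound 1 to compound 2 (0.02 log units; within the scatter). Compound 3, `Cc1ccc(-c2nnc(SCCn3c([N+](=O)[O-])cnc3C)o2)c(O)c1`, carries a different aryl group, and the two cores differ by 2-hydroxy-4-methylphenyl in place of 2-methylphenyl on an aromatic carbon. In this assay compound 3 gives 36700 nM; the steps of a 1.1-fold higher number from compound 1 to compound 3 (0.06 log units; within the scatter) and a 1.2-fold higher number from compound 2 to compound 3 (0.08 log units; within the scatter) both stay within the scatter, so no ordering among the three can be drawn. Compound 4, `COc1ccc(-c2nnc(SCCn3c([N+](=O)[O-])cnc3C)o2)c(O)c1`, is not yet measured; from compound 3 it differs by methoxy in place of methyl on an aromatic carbon. The group that leaves and the group that enters match the pair of compound 1 and compound 2, but the place is not the same: there the methoxy is ortho to a large group, here it is meta to a hydroxy group and para to a large group, so this is the same kind of change rather than the same change. Resting on a 1.1-fold lower number from compound 1 to compound 2 (0.02 log units; within the scatter), the step of a 1.1-fold lower number from compound 3 to compound 4 (0.05 log units; within the scatter) is expected to be small. Compound 4 is accordingly expected to give about 33000 nM, within a likely span from 15000 nM to 70000 nM.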

Compound 4, half-maximal inhibitory concentration: 11700 nM
For compound 4 the middle estimate is 2.8-fold (0.45 log units) above the measured one; measured number outside the range, below it.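

In this assay, methoxy in place of methyl, meta to a hydroxy group and para to a large group, gives a 3.1-fold lower number from compound 3 to compound 4 (0.50 log units; beyond the scatter), and the step seen on the core of compound 1 does not predict its size here: the same change on two cores in this assay, a 1.1-fold lower number (0.02 log units; within the scatter) from compound 1 to compound 2 and a 3.1-fold lower number (0.50 log units; beyond the scatter) from compound 3 to compound 4, 3.0-fold (0.47 log units) apart, beyond the scatter of two such steps

So in this series the size of the step cannot be assumed to carry from one core to another, even though the group that leaves and the group that enters are the same. The result does not show why the two steps differ, since the two pairs differ both in the place of the change and in the hydroxy group present only in the second pair, and a single pair on each core cannot separate these or establish a general trend.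

The compounds shown leave open whether the larger step depends on the hydroxy group, which an amine or a plain hydrogen at that place would test. They also leave open whether an ethoxy group or a chlorine atom in place of the methoxy would give a similar step on this core.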